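Replacing the ring amine benzyl group of compound 1 with a thiourea

This account rests on a few compounds, and the source may have more. Where it says the series, first, only, none or still open, it means among the compounds named here.

Compound 1, `NC(=O)c1c(NC(=O)c2ccccc2Cl)sc2c1CCN(Cc1ccccc1Cl)C2`, is one of three compounds whose antiproliferative activity has been measured in a functional assay on HL-60 cells (Homo sapiens) for antiproliferative activity, with a stated time of 24 h (a lower number here means a stronger inhibitor, a higher number a weaker inhibitor), where compound 1 gives 2900 nM. Compound 2, `Cc1ccc(C(=O)Nc2sc3c(c2C(N)=O)CCN(Cc2c(Cl)cccc2Cl)C3)cc1`, gives 10000 nM in this assay, and compound 3, `NC(=O)c1c(NC(=O)c2ccccc2F)sc2c1CCN(Cc1c(Cl)cccc1Cl)C2`, gives 10300 nM. Compound 1 therefore stands lowest of the three numbers, beyond the scatter from both compound 2 and compound 3. Going by the values given here, the only step between measured compounds that differ in one place is a 1.0-fold higher number from compound 2 to compound 3 (0.01 log units; within the scatter), a change on the carbonyl carbon of the amide.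

Compound 4, `Cc1ccccc1NC(=S)N1CCc2c(sc(NC(=O)c3ccccc3Cl)c2C(N)=O)C1`, has not yet been measured in this assay. It differs from compound 1 in a single place: a group of 10 heavy atoms (8 carbon, 1 nitrogen, 1 sulfur; one six-membered aromatic ring of carbon only) in place of a group of 8 heavy atoms (7 carbon, 1 chlorine; one six-membered aromatic ring of carbon only), on an amine nitrogen in a ring. No measured step touches the amine nitrogen in the ring, so nothing shown bears directly on this change; the one step that is shown concerns a different part of the shared core and lies within the scatter. There is thus no basis in the data for expecting a step in this assay in either direction beyond the scatter. Compound 4 is accordingly estimated at 4000 nM, within a range of 1000 nM to 16000 nM, which corresponds to an expected step of a 1.4-fold higher number from compound 1 to compound 4 (0.14 log units; within the scatter).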

Compound 4, half-maximal inhibitory concentration: 22600 nM
Compound 4: middle estimate off by 5.7-fold (0.75 log units), on the low side; measured number outside the range, above it.
By their numbers in this assay, from the lowest: compound 1; then compounds 2 and 3 (each within the scatter of the next); then compound 4.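

Going by these compounds alone, the amine nitrogen in the ring, which no earlier step touched, proves sensitive in this assay: there is a 7.8-fold higher number from compound 1 to compound 4 (0.89 log units; beyond the scatter) when the 2-chlorobenzyl group gives way to the thiourea, so the result favours the 2-chlorobenzyl group of the two at this position. This is the only step shown that lies beyond the scatter, since the one earlier step, on a carbonyl carbon, stayed within it. The entering group differs from the 2-chlorobenzyl group in several ways at once, with a hydrogen-bond donor, a hydrogen-bond acceptor, a double bond outside aromatic rings and a sulfur atom, and nothing measured here explains the step or singles out which of these differences matters.

From the compounds shown here alone, it remains open whether a urea, with oxygen in place of the thiourea sulfur, or a simple benzyl group without chlorine on the same nitrogen would stand nearer to compound 1 or to compound 4. Within the data shown here, also open is whether the step would have the same size with another group on the amide carbonyl, such as 2-fluorophenyl or 4-methylphenyl, in place of the one shared by compound 1 and compound 4.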